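Methyl for hydroxy on the piperidine ring carbon

The source may hold more compounds than are shown below. What is called first, only, known or untested is meant among the compounds shown, and "the series" means these compounds.

Measured compounds:
compound 1, `CC(C)c1nc(C(=O)NCC2(O)CCN(CC3CCOCC3)CC2)c2ccccn12`, 34%
compound 2, `CC(C)c1nc(C(=O)NCC2(O)CCN(CC(C)(C)O)CC2)c2ccccn12`, 41%

In a functional assay on CHO cells for agonist activity at 5-hydroxytryptamine receptor 4 (Homo sapiens), read by a luciferase reporter and cAMP accumulation, with a stated time of 4 h (a higher number here means a larger maximal response, a lower number a smaller maximal response), compound 1 gives 34%, the lower of the two numbers shown. Compound 2 gives 41%, and the step of a number 7 percentage points higher from compound 1 to compound 2 (within the scatter) is within the scatter, so the two values cannot be placed in order.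

Compound 3, `CC(C)c1nc(C(=O)NCC2(C)CCN(CC3CCOCC3)CC2)c2ccccn12`, has not yet been measured. It differs from compound 1 by methyl in place of hydroxy on a saturated ring carbon. Whatever the ring nitrogen carries, the only measured step, a number 7 percentage points higher from compound 1 to compound 2 (within the scatter), concerns a change on a saturated chain carbon bound to that nitrogen, not on the ring carbon that bears the hydroxy group. Among the measured compounds shown here, no measured pair therefore bears on the change from hydroxy to methyl at that ring carbon, and the data give no direction for it.

With nothing to push the number either way, the expected step is a number 2 percentage points lower from compound 1 to compound 3 (within the scatter), that is none beyond the scatter, though with wide uncertainty. Compound 3 is therefore estimated at 32%, within a range from 12% to 52%.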

Compound 3, largest response reached (Emax), in percent of the reference or control that the assay uses: 56%
Compound 3: middle estimate off by 24 percentage points, on the low side; the measured number lies above the stated range.
By their numbers in this assay, from the lowest: compounds 1 and 2 (each within the scatter of the next); then compound 3.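

The ring carbon that bears the hydroxy group proves to be a place where this assay responds to a change: methyl in place of hydroxy gives a number 22 percentage points higher from compound 1 to compound 3 (beyond the scatter) and so moves the maximal response by more than the usual scatter. The earlier step of a number 7 percentage points higher from compound 1 to compound 2 (within the scatter) on the chain carbon could not be told from that scatter, whereas this one can, and it shows that the hydroxy group on the ring carbon is not required for a response, at least with the (oxan-4-yl)methyl group in place on the ring nitrogen. No measurement offered here explains the rise, so the result stands as an observation without a cause.

The change removes a hydrogen-bond donor and a hydrogen-bond acceptor and adds a carbon, and a single pair cannot separate these differences. As far as these compounds go, it remains open whether methyl has the same effect when the ring nitrogen carries the 1-hydroxy-1-methylethyl chain of compound 2, and how hydrogen, fluorine, methoxy or ethyl would compare on the same ring carbon.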